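Bromo for Hydrogen on a Shared Core

The source may report more compounds than this note shows. Statements on the series, on what has been measured and on what is new or still open speak of the compounds shown alone.

Compound 2 `COc1ccc2[nH]c(=O)c(-c3nc4ccccc4[nH]3)cc2c1` and compound 1 `COc1ccc2[nH]c(=O)c(-c3nc4cc(Cl)ccc4[nH]3)cc2c1` share one core and differ only in one group on an aromatic carbon, a hydrogen in compound 2 where compound 1 carries a chloro. In an ADME assay on L02 cells (Homo sapiens) for cytotoxicity, read by MTT assay, with a stated time of 48 h (a higher number here means a weaker inhibitor, a lower number a stronger inhibitor), compound 2 gives > 100000 nM, which is a limit of the assay and not a number. In this assay compound 1 gives > 100000 nM, likewise a limit and not a number. Among the compounds with values here, the step that the two limits leave unreadable from compound 1 to compound 2 is therefore unreadable, both of its ends resting at the same boundary, and the only evidence on measured steps is the limit of > 100000 nM in this assay, at which 2 of the 2 values shown sit.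

Compound 3 `COc1ccc2[nH]c(=O)c(-c3nc4cc(Br)ccc4[nH]3)cc2c1` has not yet been measured. It differs from compound 2 by bromo in place of hydrogen on an aromatic carbon. Within the data shown here, the single measured step, an exchange of chloro for hydrogen, bears on this change but has no readable size, so no direction can be taken from it. Compound 3 is expected to give about 150000 nM in this assay, within a range from 50000 nM to 500000 nM. The step that the limit leaves unreadable from compound 2 to compound 3 is estimated as none beyond the scatter, and the most probable outcome is another limit rather than a number.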

Compound 3, half-maximal inhibitory concentration: > 100000 nM
Compound 3: only a limit was reported; the forecaster's own chance of this, stated with the estimate: 80%; the middle value lies beyond the limit too.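

In this assay compound 3 gives > 100000 nM, a limit and not a number. No step among compound 1, compound 2 and compound 3 can therefore be read, and the only evidence is this: the limit of > 100000 nM in this assay, at which 3 of the 3 values shown sit.

The compounds shown leave open whether hydrogen, chloro and bromo at this place on the shared core differ at all in their effect on these cells.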